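This account rests on a few compounds, and the source may have more. Where it says the series, first, only, none or still open, it means among the compounds named here.

Measured so far in a functional assay on PC-3 cells (Homo sapiens) for antiproliferative activity, read by MTT assay, with a stated time of 24 h; on this read-out lower numbers stand for stronger inhibition and higher numbers for weaker inhibition:
- compound 1 `COc1ccc(-c2noc(-c3ccncc3)n2)cc1OC1CCCC1`: > 1000000 nM (a limit)
- compound 2 `COc1ccc(-c2noc(C3CCNCC3)n2)cc1OC1CCCC1`: > 1000000 nM (a limit)
- compound 3 `COc1ccc(-c2noc(-c3cccnc3)n2)cc1OC1CCCC1`: > 1000000 nM (a limit)

Compound 3 gives > 1000000 nM, which is a limit and not a number. The other two compounds offer no reference number, as the whole set sits at one value: the limit of > 1000000 nM in this assay, at which 3 of the 3 values shown sit.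

Next is compound 4 `COc1ccc(-c2noc(-c3ccc(O)cc3)n2)cc1OC1CCCC1`, with 4-hydroxyphenyl in place of pyridin-3-yl on an aromatic carbon.

Three measured steps change this same place, and none gives a size: a step that the two limits leave unreadable from compound 1 to compound 2, a step that the two limits leave unreadable from compound 1 to compound 3 and a step that the two limits leave unreadable from compound 2 to compound 3. Among the measured compounds shown here, no measured compound carries 4-hydroxyphenyl here. Going by these compounds, the expectation in this assay is therefore no readable change, with compound 4 most likely staying at the limit, although a move toward stronger inhibition remains open.

For compound 4 the expected step is a number no higher from compound 3 to compound 4 (the limit leaves the size open).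

For compound 4 the estimate is 1000000 nM, with an estimated range from 150000 nM to 2000000 nM.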

Compound 4, half-maximal inhibitory concentration: 162000 nM
For compound 4 the middle estimate is 6.2-fold (0.79 log units) above the measured one; the range from low to high includes it.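

In this assay, this position, on an aromatic carbon of a five-membered aromatic ring with 2 nitrogen and 1 oxygen, now yields readable steps: 4-hydroxyphenyl gives an at least 6.1-fold lower number from compound 3 to compound 4 (0.79 log units; beyond the scatter), an at least 6.1-fold lower number from compound 2 to compound 4 (0.79 log units; beyond the scatter) and an at least 6.1-fold lower number from compound 1 to compound 4 (0.79 log units; beyond the scatter). Among the compounds shown here, the group at this position can therefore move the read-out, which the earlier steps, all unreadable, could not show. Compound 4 is the only compound shown with a number, and the others share one limit: the limit of > 1000000 nM in this assay, at which 3 of the 4 values shown sit.

The change from pyridin-3-yl to 4-hydroxyphenyl swaps a ring with 1 hetero atom for a ring of carbon only and adds 1 hydrogen-bond donor, and the compounds shown do not separate these two changes. Phenyl without the hydroxyl, or 4-methoxyphenyl, would bear on that question, and the true size of each step remains open.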